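Adding a hydroxy to the side chain of a lactone

The compounds below may be only part of what the source reports. "The series", "measured", "known", "first", "only" and "open" are said of these compounds alone.

Of the compounds shown here, three of this set have been tested in a functional assay on A2780 ADR cells (Homo sapiens) for cytotoxicity, read by MTT assay, with a stated time of 24 h; on this read-out lower numbers stand for stronger inhibition and higher numbers for weaker inhibition. Compound 1 `CCCCC[C@H](C[C@H](O)C[C@H]1CC=CC(=O)O1)OC` gives 57500 nM. Compound 2 `CCCCC[C@@H](C[C@@H](O)C[C@H]1CC=CC(=O)O1)OC` shares its atoms and bonds with compound 1 and differs only in how two stereocentres are drawn; in this assay compound 2 gives 25200 nM. Compound 3 `CCCCC[C@@H](CCC[C@@H]1CC=CC(=O)O1)OC`, which carries no hydroxy on its side chain, gives 11500 nM, the lowest number of the three, beyond the scatter from both others.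

For the measured compounds named here, the one step measured so far, a 2.3-fold lower number from compound 1 to compound 2 (0.36 log units; beyond the scatter), rests on the fact that compounds 1 and 2 differ only in the configuration as drawn alone and says nothing about adding or removing a group.

Compound 4 `CCCCC[C@@H](C[C@@H](O)C[C@@H]1CC=CC(=O)O1)OC` is not yet measured. It differs from compound 3 by hydroxy in place of hydrogen on a saturated chain carbon bound to two saturated chain carbons. Going by the values given here, no measured step follows exactly this change. What the numbers show is that the two compounds bearing the hydroxy, compound 1 and compound 2, gave higher numbers than compound 3, though they also differ from it in configuration, so this is weak guidance. On that basis a modest rise in the number is expected for compound 4, a step of a 1.7-fold higher number from compound 3 to compound 4 (0.24 log units; within the scatter). Compound 4 is therefore estimated at 20000 nM, in a range from 8000 nM to 50000 nM.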

Compound 4, half-maximal inhibitory concentration: 46300 nM
Compound 4: the middle estimate sits 2.3-fold (0.36 log units) below what was measured, and the stated range covers the measured number.
By their numbers in this assay, from the lowest: compound 3; then compounds 2, 4 and 1 (each within the scatter of the next, the first and the last beyond it).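

In this assay, for the compounds shown here, hydroxy in place of hydrogen on a saturated chain carbon bound to two saturated chain carbons gives a 4.0-fold higher number from compound 3 to compound 4 (0.60 log units; beyond the scatter), the first measured step of this exact change, and it points to weaker inhibition with the hydroxy present. Inverting the ring stereocentre alone does not separate two compounds bearing the hydroxy, since a 1.8-fold higher number from compound 2 to compound 4 (0.26 log units; within the scatter) stays within the scatter, and this pair is a direct test of configuration: the fact that compounds 2 and 4 differ only in the configuration as drawn Full inversion does not separate them either, with a 1.2-fold lower number from compound 1 to compound 4 (0.09 log units; within the scatter) also within the scatter for a pair of mirror images: the fact that compounds 1 and 4 differ only in the configuration as drawn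

This single pair cannot show whether the hydroxy step would be the same size with the side chain or ring stereocentres drawn the other way, since compound 3 appears in only one configuration. The compounds shown also leave open what an amine or a fluorine on that saturated chain carbon would give, and whether a longer chain would change the size of the step.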